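Heterocycle swap on two related cores

A few compounds are considered here, and "the series" means these few. Any claim that something is new, unique, unknown or untested is made for them only; others in the source may bear on it.

Compound 1 `Nc1ccn(C[C@H](O)[C@H]2OC(=O)C(OCc3ccccc3)=C2OCc2ccccc2)c(=O)n1` and compound 2 `Nc1ccn(CCC2(N)OC(=O)C(OCc3ccccc3)=C2OCc2ccccc2)c(=O)n1` differ in their cores; the difference between the two cores is not broken down here. In a functional assay on HeLa cells (Homo sapiens) for inhibition, read by MTT assay, with a stated time of 72 h (on this read-out lower numbers stand for stronger inhibition and higher numbers for weaker inhibition), compound 1 gives > 100000 nM, which is a limit of the assay. Compound 2 gives > 100000 nM in this assay, again a limit. Compound 3 `NC1(CCn2c(=O)[nH]c(=O)[nH]c2=O)OC(=O)C(OCc2ccccc2)=C1OCc1ccccc1` arises from compound 2 by a group of 9 heavy atoms (3 carbon, 3 nitrogen, 3 oxygen; one six-membered aromatic ring with 3 hetero atoms) in place of a group of 8 heavy atoms (4 carbon, 3 nitrogen, 1 oxygen; one six-membered aromatic ring with 2 hetero atoms), on a saturated chain carbon, two bonds along the chain from a saturated ring carbon; in this assay compound 3 gives 77100 nM, a step of an at least 1.2-fold lower number from compound 2 to compound 3 (0.11 log units; that floor lies within the scatter). Compound 4 `O=C1O[C@H]([C@@H](O)Cn2c(=O)[nH]c(=O)[nH]c2=O)C(OCc2ccccc2)=C1OCc1ccccc1` arises from compound 1 by a group of 9 heavy atoms (3 carbon, 3 nitrogen, 3 oxygen; one six-membered aromatic ring with 3 hetero atoms) in place of a group of 8 heavy atoms (4 carbon, 3 nitrogen, 1 oxygen; one six-membered aromatic ring with 2 hetero atoms), on a saturated chain carbon, two bonds along the chain from an oxygen on a saturated carbon and a saturated ring carbon, the same kind of change, though here the chain carbon also stands two bonds along the chain from an oxygen on a saturated carbon. Because the limit of > 100000 nM in this assay, at which 2 of the 3 values shown sit, leaves the measured step only a floor, compound 4 is expected to shift by about an at least 1.1-fold lower number from compound 1 to compound 4 (0.07 log units; that floor lies within the scatter), within the scatter. Compound 4 is estimated at 85000 nM in this assay, between 30000 nM and 200000 nM, with a fair chance that only a limit is reported.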

Compound 4, half-maximal inhibitory concentration: > 100000 nM
Compound 4 gave a limit, no number (the forecaster's own chance of this, stated with the estimate: 55%); middle value at least 1.1-fold (0.07 log units) away from the limit.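

No step can be read between compound 1 and compound 4: both values are limits, not numbers. The compounds shown leave open how far this heterocycle swap shifts the read-out on either core, given this limit: the limit of > 100000 nM in this assay, at which 3 of the 4 values shown sit.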